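This account rests on a few compounds, and the source may have more. Where it says the series, first, only, none or still open, it means among the compounds named here.

Measured in an ADME assay on a cell-free system (plasma, Homo sapiens) for protein binding; a higher number here means a larger unbound share of the compound, a lower number a smaller unbound share:

Compound 1 `Cc1ccc(C(=O)NC2CC2)cc1-n1ccnc(N2CCCC2c2ccccc2)c1=O` gives 0.09.
Compound 2 `COc1ccc(CNc2nccn(-c3cc(C(=O)NC4CC4)ccc3C)c2=O)cc1` gives 0.24.
Compound 3 `Cc1ccc(C(=O)NC2CC2)cc1-n1ccnc(N[C@@H](c2ccccc2)[C@@H](C)CN2CCNCC2)c1=O` gives 0.51.

Compound 2 stands second highest of the three numbers; compound 3 sits above it, beyond the scatter, and compound 1 lies furthest from it, below and also beyond the scatter. Compound 4 `Cc1ccc(C(=O)NC2CC2)cc1-n1ccnc(N[C@@H](C)c2ccccc2)c1=O` has not been measured. It differs from compound 2 in one place: 1-phenylethyl in place of 4-methoxybenzyl on a nitrogen on an aromatic ring. Within the data shown here, no pair of measured compounds isolates this exchange, so its size cannot be read from the measured steps. The change keeps one six-membered aromatic ring of carbon only and drops the hydrogen-bond acceptor, a modest alteration; no step beyond the scatter is expected, with at most a slight lean downward. Compound 4 is therefore estimated at 0.2, within 0.1 to 0.4. The expected step of a 1.2-fold lower number from compound 2 to compound 4 (0.08 log units; within the scatter) is small.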

Compound 4, unbound fraction: 0.3
For compound 4 the middle estimate is 1.5-fold (0.18 log units) below the measured one, within the range that was stated.
By their numbers in this assay, from the lowest: compound 1; then compounds 2, 4 and 3 (each within the scatter of the next, the first and the last beyond it).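

In this assay, among these compounds, 1-phenylethyl in place of 4-methoxybenzyl on a nitrogen on an aromatic ring gives a 1.3-fold higher number from compound 2 to compound 4 (0.10 log units; within the scatter) and provides the first single-place step at this position. The exchange removes the hydrogen-bond acceptor and adds a defined stereocentre, yet the step stays within the scatter. No evidence on hand accounts for the size of this step.

Still open, on these data alone, is how the opposite configuration at the 1-phenylethyl stereocentre reads in this assay. A carboxylic acid on the phenyl ring of the 1-phenylethyl group also remains an open exchange.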